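Chloro for methoxy on a quinolinone core: lipophilicity notes

The source may hold more compounds than are shown below. What is called first, only, known or untested is meant among the compounds shown, and "the series" means these compounds.

Compound 1 `CCCCC#Cc1c(C)[nH]c2ccc(OC)cc2c1=O` gives 5.25 in a physicochemical assay for lipophilicity, at pH 7.4; a lower number here means a more polar compound, a higher number a more lipophilic compound. Compound 2 `CCCCC#Cc1c(C)[nH]c2ccc(Cl)cc2c1=O` gives 2.98; the change chloro in place of methoxy on an aromatic carbon made a step of a number 2.27 log units lower from compound 1 to compound 2 (beyond the scatter). Compound 3 `COc1ccc2[nH]c(C)c(Cc3ccccc3)c(=O)c2c1` gives 2.53, the lowest of the three, after benzyl in place of hex-1-yn-1-yl on an aromatic carbon and a step of a number 2.72 log units lower from compound 1 to compound 3 (beyond the scatter); this is how the cores of compound 1 and compound 3 differ. Compound 4 `Cc1[nH]c2ccc(Cl)cc2c(=O)c1Cc1ccccc1` is unmeasured and carries the same change as compound 2, namely (chloro in place of methoxy on an aromatic carbon).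

The earlier step started from compound 1 at 5.25, far above compound 2 at 2.98 and compound 3 at 2.53, which stand close. Because compound 3 already stands at 2.53, a smaller step is expected, a number 0.27 log units higher from compound 3 to compound 4 (within the scatter). For compound 4 the estimate in this assay is 2.8, between 1.6 and 3.6.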

Compound 4, distribution coefficient: 2.79
Compound 4: the middle estimate sits 0.01 log units above what was measured; measured number inside the range.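

In this assay, chloro in place of methoxy on an aromatic carbon gives a number 0.26 log units higher from compound 3 to compound 4 (within the scatter), within the scatter, on the core of compound 3. The same change gives a number 2.27 log units lower from compound 1 to compound 2 (beyond the scatter), beyond the scatter, on the core of compound 1, so the size of the step does not carry from one core to the other in these two pairs. This shows only that the step depends on the core in these two pairs, not how it would behave on any further core, and no measurement shown accounts for the gap between the steps.

Open, from the compounds shown here alone, is how the same change behaves when an amine or a carboxylic acid stands in place of benzyl or hex-1-yn-1-yl. Also open, going by these compounds, is where a replacement such as trifluoromethyl would fall on either core.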